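A few compounds are considered here, and "the series" means these few. Any claim that something is new, unique, unknown or untested is made for them only; others in the source may bear on it.

Compound 2, `CC1CCCCN1c1ncc2[nH]nc(-c3ccc(N4CCN[C@H](C)C4)nc3)c2n1`, has the lowest number of the three measured in an assay on Sf9 cells for inhibition of activin receptor type-1 (Homo sapiens), read by HTRF, with a stated time of 3 h, in the presence of a further agent that is not named here; on this read-out lower numbers stand for stronger inhibition and higher numbers for weaker inhibition: compound 2 gives 8.1 nM, while compound 1, `C[C@@H]1CN(c2ccc(-c3n[nH]c4cnc(N5[C@H](C)COC[C@@H]5C)nc34)cn2)CCN1`, gives 23 nM and compound 3, `C[C@@H]1CN(c2ccc(-c3n[nH]c4ccc(N5CCCCC5)nc34)cn2)CCN1`, gives 95 nM. Among the compounds with values here, the single measured step that reaches compound 2 is a 2.8-fold lower number from compound 1 to compound 2 (0.45 log units; beyond the scatter).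

Compound 4, `C[C@@H]1CN(c2ccc(-c3n[nH]c4cnc(N5CCCCC5)nc34)cn2)CCN1`, differs from compound 2 by hydrogen in place of methyl on a saturated ring carbon. Within the data shown here, no measured pair shows this exact change, so the expectation rests on indirect evidence. The step from compound 1 to compound 2 shows that the group on the shared core matters, since a change there moved the number beyond the scatter. Compound 3 carries piperidin-1-yl, the same group that enters in compound 4, but sits on a different core. In this assay compound 3 gives 95 nM. In this assay compound 2 gives 8.1 nM. These two values cannot be read as a single-place step; the value of compound 3 is noted only as a weaker number for a compound bearing the unsubstituted ring.

Taken together, a modest rise in the number, beyond the scatter but well short of the gap to compound 3, is expected for compound 4, amounting to a 2.5-fold higher number from compound 2 to compound 4 (0.39 log units; beyond the scatter). The estimate for compound 4 in this assay is therefore 20 nM, with a range from 6 nM to 65 nM.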

Compound 4, half-maximal inhibitory concentration: 40 nM
Estimate against measurement, compound 4: 2.0-fold (0.30 log units) below; the measured number falls inside the stated range.
By their numbers in this assay, from the lowest: compound 2; then compounds 1 and 4 (each within the scatter of the next); then compound 3.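

In this assay, within the data shown here, the change from 2-methylpiperidin-1-yl to piperidin-1-yl is a 4.9-fold higher number from compound 2 to compound 4 (0.69 log units; beyond the scatter), which shows for the first time that this one methyl, on a saturated ring carbon next to the ring nitrogen, changes the number beyond the scatter on the shared core. The other new step, a 1.7-fold higher number from compound 1 to compound 4 (0.24 log units; within the scatter), places the unsubstituted ring within the scatter of the 3,5-dimethylmorpholin-4-yl group, so among these three compounds on the shared core, only compound 2, the one bearing 2-methylpiperidin-1-yl, stands apart from the others. Nothing available here accounts for the size of either step.

The compounds shown leave open whether an ethyl, a hydroxymethyl or a fluorine at the same ring carbon would give a number like that of compound 2, and whether a second methyl, as in 2,6-dimethylpiperidin-1-yl, would lower it further. They also leave open whether adding the same methyl to the piperidin-1-yl group of compound 3, on its different core, would produce a step of similar size.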